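The compounds below may be only part of what the source reports. "The series", "measured", "known", "first", "only" and "open" are said of these compounds alone.

Measured compounds in a functional assay on MCF7 cells (Homo sapiens) for cytotoxicity, read by sulforhodamine B assay, with a stated time of 48 h; on this read-out lower numbers stand for higher toxicity in this test and higher numbers for lower toxicity in this test:
compound 1 `ClCc1cccc(Cn2cnc3ncnc(Cl)c32)c1` gives 39000 nM.
compound 2 `ClCc1ccccc1Cn1cnc2ncnc(Cl)c21` gives > 100000 nM, which is a limit of the assay.
compound 3 `ClCc1cccc(Cn2cnc3nc(Cl)nc(Cl)c32)c1` gives > 100000 nM, which is a limit of the assay.

Compound 1 and compound 2 are built from the same atoms joined differently; the difference between the two cores is not broken down here. Compound 3 carries the change chloro in place of hydrogen on an aromatic carbon relative to compound 1, and the step of an at least 2.5-fold higher number from compound 1 to compound 3 (0.40 log units; beyond the scatter) reads as lower toxicity. The unmeasured compound 4 `ClCc1ccccc1Cn1cnc2nc(Cl)nc(Cl)c21` stands to compound 2 as compound 3 stands to compound 1: the same change (chloro in place of hydrogen on an aromatic carbon), at the same place. Because compound 2 already sits at the limit of > 100000 nM in this assay, at which 2 of the 3 values shown sit, the step that the limit leaves unreadable from compound 2 to compound 4 expected in this assay can only show as a limit once more. For compound 4 the result in this assay is expected at 200000 nM, most likely reported as a limit only.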

Compound 4, concentration lethal to 50% of the cells: > 100000 nM
Compound 4: a limit, no number (the forecaster's own chance of this, stated with the estimate: 90%); the middle value is on the limit's open side.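

Compound 2 and compound 4 are both limits, not numbers, in this assay, so no step can be read between them: the limit of > 100000 nM in this assay, at which 3 of the 4 values shown sit.

As far as these compounds go, whether chloro in place of hydrogen on an aromatic carbon changes toxicity on the core of compound 2 stays open.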